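Chain extension on the difluoroacyl amide of a shared core

The compounds below may be only part of what the source reports. "The series", "measured", "known", "first", "only" and "open" are said of these compounds alone.

Compound 1, `Cc1nc(S(C)(=O)=O)ccc1Oc1ncnc(OC2CCN(C(=O)OC3(C(F)(F)F)COC3)CC2)c1F`: 342 nM
Compound 2, `Cc1nc(S(C)(=O)=O)ccc1Oc1ncnc(OC2CCN(C(=O)C(C)(F)F)CC2)c1F`: 239 nM

In a functional assay on isolated protein for inhibition of Glucose-dependent insulinotropic receptor (Rattus norvegicus), read by HTRF and cAMP accumulation (a lower number here means that less compound is needed, a higher number that more compound is needed for the effect), compound 2 gives 239 nM. Within the data shown here, compound 2 stands within the scatter of its only neighbour, compound 1: a 1.4-fold lower number from compound 1 to compound 2 (0.16 log units; within the scatter). Compound 3, `CCC(F)(F)C(=O)N1CCC(Oc2ncnc(Oc3ccc(S(C)(=O)=O)nc3C)c2F)CC1`, differs from compound 2 by methyl in place of hydrogen on a saturated chain carbon, two bonds along the chain from a carbonyl carbon and two fluorine atoms. Among the measured compounds shown here, no measured step touches this chain; the single measured step, a 1.4-fold lower number from compound 1 to compound 2 (0.16 log units; within the scatter), concerns a different group and lay within the scatter. Compound 3 is therefore expected to sit close to compound 2, an expected step of a 1.0-fold higher number from compound 2 to compound 3 (0.00 log units; within the scatter). The estimate for compound 3 in this assay is 240 nM, with a range from 100 nM to 600 nM.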

Compound 3, half-maximal effective concentration: 69.2 nM
Beside the measured number, compound 3's estimate is 3.5-fold (0.54 log units) above it, and the stated range ends above it.
By their numbers in this assay, from the lowest: compound 3; then compounds 2 and 1 (each within the scatter of the next).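

In this assay, among these compounds, methyl in place of hydrogen on this saturated chain carbon gives a 3.5-fold lower number from compound 2 to compound 3 (0.54 log units; beyond the scatter), the first step at this chain and the first beyond the scatter. The 1,1-difluoropropyl group also separates from (3-(trifluoromethyl)oxetan-3-yl)oxy, with a 4.9-fold lower number from compound 1 to compound 3 (0.69 log units; beyond the scatter), which 1,1-difluoroethyl did not do. No measurement available here accounts for this change. On these data alone, whether a longer chain, such as 1,1-difluorobutyl, would lower the number further stays open. So does the outcome with a cyclopropyl group in place of the added methyl.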